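This account rests on a few compounds, and the source may have more. Where it says the series, first, only, none or still open, it means among the compounds named here.

Measured compounds:
- Compound 1, `CCCCc1ccc(CNC(C)=O)c(=O)n1Cc1ccc(-c2ccccc2-c2nn[nH]n2)cc1`; in a functional assay (aorta) for antagonist activity, with Oryctolagus cuniculus as the target (a higher number here means a weaker inhibitor, a lower number a stronger inhibitor), compound 1 gives 3 nM.
- Compound 2, `CCCCc1ccc(CN(Cc2ccccc2)C(C)=O)c(=O)n1Cc1ccc(-c2ccccc2-c2nn[nH]n2)cc1`; compound 2 gives 1 nM.
- Compound 3, `CCCCc1cccc(=O)n1Cc1ccc(-c2ccccc2-c2nn[nH]n2)cc1`; compound 3 gives 4 nM.

Compound 3 carries the highest of the three numbers. Its nearest neighbour is compound 1, reached by a 1.3-fold higher number from compound 1 to compound 3 (0.12 log units; within the scatter), a step within the scatter, so the two cannot be ordered. Compound 2 is further off: a 4.0-fold higher number from compound 2 to compound 3 (0.60 log units; beyond the scatter) lies beyond the scatter. The step of a 3.0-fold lower number from compound 1 to compound 2 (0.48 log units; beyond the scatter) shows the same modest gain when a benzyl replaces hydrogen on the amide-type nitrogen.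

Compound 4, `CCCCc1ccc(C)c(=O)n1Cc1ccc(-c2ccccc2-c2nn[nH]n2)cc1`, differs from compound 3 by methyl in place of hydrogen on an aromatic carbon. Among the compounds with values here, the steps that bear on this position are those where a substituent on that aromatic carbon is replaced by hydrogen: the acetamidomethyl case is within the scatter, the (acetyl(benzyl)amino)methyl case costs a modest amount. Methyl is smaller than either group that has been tried there, so the expected step of a 1.3-fold lower number from compound 3 to compound 4 (0.12 log units; within the scatter) is small, at most a slightly lower number, and is likely to fall within the scatter. Compound 4 is estimated at 3 nM, with a range of 1.5 nM to 8 nM.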

Compound 4, half-maximal inhibitory concentration: 7 nM
Compound 4: middle estimate off by 2.3-fold (0.37 log units), on the low side; measured number inside the range.
By their numbers in this assay, from the lowest: compound 2; then compounds 1, 3 and 4 (each within the scatter of the next, the first and the last beyond it).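

Methyl in place of hydrogen on the aromatic carbon para to the butyl group gives a 1.8-fold higher number from compound 3 to compound 4 (0.24 log units; within the scatter), so at this position the smallest substituent shown cannot be told apart from hydrogen. The saturated chain carbon bound to that aromatic carbon tells more: hydrogen in place of acetamido there gives a 2.3-fold higher number from compound 1 to compound 4 (0.37 log units; beyond the scatter), and hydrogen in place of acetyl(benzyl)amino gives a 7.0-fold higher number from compound 2 to compound 4 (0.85 log units; beyond the scatter), so both amides stand apart from plain methyl, although compound 1 and compound 3 could not be ordered. No measurement on the series accounts for these steps.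

Still open, on these data alone, is whether a primary amine or a carboxylic acid on that chain carbon would fall with compound 2 or with compound 4. Also open, as far as these compounds go, is whether benzylamino without the acetyl, or a longer chain such as ethyl or propyl, would match the amides.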